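The source may hold more compounds than are shown below. What is called first, only, known or untested is meant among the compounds shown, and "the series" means these compounds.

Two compounds measured in an assay on isolated protein for binding affinity to melatonin receptor type 1B (Homo sapiens) (a lower number here means a stronger inhibitor, a higher number a weaker inhibitor), set the starting point. Compound 1, `CCCC(=O)Nc1cccc(Oc2cccc(OC)c2)c1`, gives 26.8 nM in this assay. Among the measured compounds shown here, compound 2, `CCC(=O)Nc1ccc(Oc2cccc(OC)c2)cc1`, gives 6.8 nM in this assay, the lowest of the two numbers; its nearest neighbour is compound 1, whose number is higher by a margin that lies beyond the scatter of repeated measurements, so compound 2 stands as the stronger binder of the pair on the numbers so far.

The step now taken leads from compound 2 to compound 3, `COCC(=O)Nc1ccc(Oc2cccc(OC)c2)cc1`. The change is a single one: methoxy in place of methyl on a saturated chain carbon bound to a carbonyl carbon. For the measured compounds named here, no step between two measured compounds of this kind exists here, so no measured precedent tells how this assay responds to it; the expectation below rests only on the two values above and on the change itself.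

Compound 3 is expected to bind somewhat less tightly than compound 2 while staying in the same region, with an estimated step of a 2.2-fold higher number from compound 2 to compound 3 (0.34 log units; beyond the scatter) in this assay. The estimate for compound 3 in this assay is 15 nM, within a range from 5 nM to 45 nM.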

Compound 3, inhibition constant: 5.9 nM
The estimate for compound 3 lay 2.5-fold (0.41 log units) above the measured number; the measured number falls inside the stated range.
By their numbers in this assay, from the lowest: compounds 3 and 2 (each within the scatter of the next); then compound 1.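

The first step measured at this place, methoxy in place of methyl on a saturated chain carbon bound to a carbonyl carbon, comes to a 1.2-fold lower number from compound 2 to compound 3 (0.06 log units; within the scatter) in this assay, so this read-out cannot tell compound 2 and compound 3 apart. The position therefore accepts a group of two heavy atoms, one of them an oxygen counted as a hydrogen-bond acceptor, in place of a single carbon, with binding still as tight as in compound 2; seen one bond further out, the same change is ethyl to methoxymethyl. Nothing at hand says why the number holds steady through this change.

On these data alone, whether a longer chain, an amine or a carboxylic acid on that same saturated chain carbon would also keep the number in this range remains open, as a single step says little about groups that differ more from methyl. Compound 1 differs from compound 2 in more than one place, so the separate contributions of the chain length and of where the amide sits on the core also remain unresolved.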